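Replacing a Pyridyl Ring with a Pyridyloxy Group

The source may report more compounds than this note shows. Statements on the series, on what has been measured and on what is new or still open speak of the compounds shown alone.

Measured compounds:
compound 1 `CNC(=O)c1ccc2noc(-c3ccccc3)c2c1`: 6830 nM
compound 2 `O=C(O)c1ccc2noc(-c3ccc(-c4cccnc4)cc3)c2c1`: 610 nM

In an assay for inhibition of inositol hexakisphosphate kinase 3 (Homo sapiens), read by colorimetric assay, coupled enzyme assay and malachite green, with a stated time of 120 min, in the presence of a further agent that is not named here (a lower number here means a stronger inhibitor, a higher number a weaker inhibitor), compound 1 gives 6830 nM, while compound 2 gives 610 nM. Compound 2 therefore stands lowest of the two numbers, and its distance from compound 1 lies beyond the usual scatter of this assay. Among the measured compounds shown here, the two compounds differ in more than one place, so no single step between them can be read off.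

Compound 3 `O=C(O)c1ccc2noc(-c3ccc(Oc4ccccn4)cc3)c2c1` keeps the carboxylic acid and the shared core of compound 2 and changes only the group on the outer ring: (pyridin-2-yl)oxy in place of pyridin-3-yl on an aromatic carbon. For the measured compounds named here, no measured pair shows a change of this kind, so the direction of the step is open. Because compound 2 already gives 610 nM, a step of modest size in either direction, or none beyond the scatter, is expected rather than a large one. The estimate for compound 3 is a step of a 1.6-fold higher number from compound 2 to compound 3 (0.21 log units; within the scatter) in this assay, which puts the expected value for compound 3 at 1000 nM, within a range from 300 nM to 4000 nM.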

Compound 3, half-maximal inhibitory concentration: 2060 nM
For compound 3 the middle estimate is 2.1-fold (0.31 log units) below the measured one; measured number inside the range.
By their numbers in this assay, from the lowest: compound 2; then compound 3; then compound 1.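

Among the compounds shown here, this is the first comparison here that differs in only one place, on an aromatic carbon para to a large group, with the carboxylic acid and the shared core held fixed. In this assay the change to (pyridin-2-yl)oxy in place of pyridin-3-yl gives a 3.4-fold higher number from compound 2 to compound 3 (0.53 log units; beyond the scatter) and so moves towards weaker inhibition. The position is therefore sensitive to this swap even though both groups carry a six-membered aromatic ring with one nitrogen, and nothing available here accounts for the direction or size of the step.

The step combines two changes, the added oxygen link and the switch from a pyridin-3-yl to a pyridin-2-yl ring, and the compounds shown cannot separate them; a (pyridin-3-yl)oxy group or a directly attached pyridin-2-yl group at this place would do so. Also open, as far as these compounds go, is how a phenoxy group, with no ring nitrogen, or an amine link in place of the oxygen would compare here.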